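From an Aminomethyl Side Chain to a Pyrrolidine Amide

The compounds below may be only part of what the source reports. "The series", "measured", "known", "first", "only" and "open" are said of these compounds alone.

The series centers on compound 2 `CC(C)=CCC[C@]1(C)/C=C/[C@@H](OC(=O)C=C(C)C)[C@](C)(O)/C=C/C(=O)/C(CN2CCN(C)CC2)=C\C1`, which in a functional assay on HL-60 cells (Homo sapiens) for antiproliferative activity, read by MTT assay, with a stated time of 48 h (on this read-out higher numbers stand for weaker inhibition and lower numbers for stronger inhibition), gives 840 nM, the lowest of the three numbers recorded. Compound 1 `CC(=O)OC/C1=C/C[C@](C)(CCC=C(C)C)/C=C/[C@@H](OC(=O)C=C(C)C)[C@](C)(OC(C)=O)/C=C/C1=O` gives 3480 nM and compound 3 `CC(C)=CCC[C@](C)(/C=C/[C@@H](OC(=O)C=C(C)C)[C@](C)(O)/C=C/C(=O)/C=C/N(C)C)CC=O` gives 4690 nM, both standing beyond the scatter from compound 2. Compound 4 `CC(C)=CCC[C@]1(C)/C=C/[C@@H](OC(=O)C=C(C)C)[C@](C)(O)/C=C/C(=O)/C(C(=O)N2CCCC2)=C\C1` has not yet been measured; it differs from compound 2 in one place ((pyrrolidin-1-yl)carbonyl in place of (4-methylpiperazin-1-yl)methyl on a double-bonded ring carbon). Among the measured compounds shown here, no step between measured compounds that differ in a single place is available, so the size of this change has no direct precedent here. The author expects a modest move toward weaker inhibition, near the edge of the scatter, as a 1.9-fold higher number from compound 2 to compound 4 (0.28 log units; within the scatter). Compound 4 is therefore estimated at 1600 nM, with a range from 450 nM to 6000 nM.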

Compound 4, half-maximal inhibitory concentration: 12300 nM
Compound 4: middle estimate off by 7.7-fold (0.89 log units), on the low side; the measured number lies above the stated range.
By their numbers in this assay, from the lowest: compound 2; then compounds 1 and 3 (each within the scatter of the next); then compound 4.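

In this assay, the double-bonded ring carbon proves sensitive to its substituent: (pyrrolidin-1-yl)carbonyl in place of (4-methylpiperazin-1-yl)methyl gives a 15-fold higher number from compound 2 to compound 4 (1.17 log units; beyond the scatter) and provides the series' first single-place comparison. This swap changes the ring and the attachment to the carbonyl together, so the step cannot be assigned to either alone. No measurement at hand explains the step. The compounds shown leave open how (pyrrolidin-1-yl)methyl or (4-methylpiperazin-1-yl)carbonyl would read at this carbon, which would separate the two changes. They also leave open how a carboxylic acid there would read.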